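Larger ketone side chain on the shared core

This account rests on a few compounds, and the source may have more. Where it says the series, first, only, none or still open, it means among the compounds named here.

Compound 1 `Cc1c(OCCCCOc2ccc(C(=O)O)c(Cl)c2)ccc(C(=O)CC(C)C)c1O`: 2050 nM
Compound 2 `CCCC(=O)c1ccc(OCCCCOc2ccc(C(=O)O)cc2C)c(C)c1O`: > 10000 nM
Compound 3 `COC(=O)c1ccc(OCCCCOc2ccc(C(=O)CC3CCCC3)c(C)c2C)cc1`: "not determined" (no result reported)

All three were run in an assay on HEK293 cells for positive allosteric modulation of metabotropic glutamate receptor 3 (Rattus norvegicus), read by thallium flux, with a stated time of 2.5 min; a lower number here means that less compound is needed, a higher number that more compound is needed for the effect. Compound 1 gives 2050 nM. Compound 2 reaches only a limit of the assay, > 10000 nM, so no single number is known for it. That is the limit of > 10000 nM in this assay, at which 1 of the 3 values shown sits. Compound 3 was run, but in this assay compound 3 stands at "not determined" (no result reported). Going by the values given here, no two of these measured compounds differ in only one place, so no measured step is available.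

Compound 4 `Cc1cc(C(=O)O)ccc1OCCCCOc1ccc(C(=O)CC2CCCC2)c(O)c1C` has not yet been measured. It differs from compound 2 by cyclopentyl in place of ethyl on a saturated chain carbon bound to a carbonyl carbon. Compound 1 gives 2050 nM. Compound 2 sits at a limit of the assay. On that basis it is expected that growth at the saturated chain carbon bound to a carbonyl carbon helps, and the step of an at least 4.0-fold lower number from compound 2 to compound 4 (0.60 log units; beyond the scatter) is expected to go toward lower numbers, beyond the usual scatter. Compound 4 is expected to give about 2500 nM, estimated between 700 nM and 10000 nM.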

Compound 4, half-maximal effective concentration: > 10000 nM
Compound 4: only a limit was reported; the forecaster's own chance of this, stated with the estimate: 30%; middle value at least 4.0-fold (0.60 log units) away from the limit.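

Compound 2 and compound 4 both sit at a limit of the assay rather than at a number, so no step can be read between them: the limit of > 10000 nM in this assay, at which 2 of the 4 values shown sit.

The compounds shown leave open whether cyclopentyl in place of ethyl at this place changes the concentration needed at all.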